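The compounds below may be only part of what the source reports. "The series", "measured", "known", "first", "only" and "open" are said of these compounds alone.

Going by the values given here, in an ADME assay on liver (Homo sapiens) for metabolic stability, read by LC-MS, using microsomes and NADPH (a lower number here means that less of the compound is left, a higher number that more of the compound is left), compound 2 (`Cc1cc(CN(CC2CCCCC2)C(CC(=O)O)c2ccc(Cl)cc2)ccc1OCCN1C(=O)CCC1=O`) gives 47%, the lower of the two numbers measured so far, and compound 1 (`CCCCN(Cc1ccc(OCCN2C(=O)CCC2=O)c(C)c1)C(CC(=O)O)c1ccc(Cl)cc1`) gives 83%.

The next change leads to compound 3 (`Cc1cc(CN(CCC(F)(F)F)C(CC(=O)O)c2ccc(Cl)cc2)ccc1OCCN1C(=O)CCC1=O`) and reads 2,2,2-trifluoroethyl in place of cyclohexyl on a saturated chain carbon bound to an amine nitrogen. Cut one bond further out, this is cyclohexylmethyl to 3,3,3-trifluoropropyl.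

Among the compounds with values here, only one measured step bears on this place: a number 36 percentage points lower from compound 1 to compound 2 (beyond the scatter). It is large, and it is the step that brought in the cyclohexyl that now leaves. Most of that loss is therefore expected to be recovered, though not necessarily all of it, as the entering group is not the propyl of compound 1. Within the data shown here, no measured compound carries fluorine on this chain, and a single step is thin support, so the range is kept wide.

In this assay the expected change is upward and large, an estimated a number 28 percentage points higher from compound 2 to compound 3 (beyond the scatter). The estimate for compound 3 is 75%, with an expected range of 58% to 92%.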

Compound 3, percent of the compound remaining: 81%
Compound 3: middle estimate off by 6 percentage points, on the low side; low and high end bracket the measured number.
By their numbers in this assay, from the lowest: compound 2; then compounds 3 and 1 (each within the scatter of the next).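

In this assay, 2,2,2-trifluoroethyl in place of cyclohexyl gives a number 34 percentage points higher from compound 2 to compound 3 (beyond the scatter), a large step of about the same size as the earlier one in the opposite direction, so the low number that came with the cyclohexyl does not persist once this ring leaves this place. Trifluoromethyl in place of ethyl on a saturated chain carbon, two bonds along the chain from an amine nitrogen, gives a number 2 percentage points lower from compound 1 to compound 3 (within the scatter), so among the three compounds shown, the two open-chain substituents cannot be told apart here and only the cyclohexylmethyl compound stands apart. No measurement at hand gives a cause for either step.

Going by these compounds alone, with only one ring-bearing compound in the set, the drop cannot yet be tied to the ring itself rather than to the size of this substituent, and a cyclopropylmethyl or a tetrahydropyranylmethyl group on the same nitrogen would separate these readings. A longer open chain such as hexyl would show whether the high numbers hold for open chains in general, and a 4,4,4-trifluorobutyl group would extend the same question to fluorinated chains.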